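Removing the Triazole Substituent: Cytotoxicity of Compound 4

The source may report more compounds than this note shows. Statements on the series, on what has been measured and on what is new or still open speak of the compounds shown alone.

Measured compounds:
Compound 1 `Cc1ccc(S(=O)(=O)NCc2cn(C[C@H](O)[C@H]3OC(=O)C(OCc4ccccc4)=C3OCc3ccccc3)nn2)cc1` gives 50 nM in an ADME assay on HFF cells (Homo sapiens) for cytotoxicity, read by MTT assay, with a stated time of 72 h; a higher number here means a weaker inhibitor, a lower number a stronger inhibitor.
Compound 2 `O=C1O[C@H]([C@@H](O)Cn2cc(-c3cc(F)cc(F)c3)nn2)C(OCc2ccccc2)=C1OCc1ccccc1` reaches only a limit of this assay, > 100000 nM.
Compound 3 `COc1ccccc1-c1cn(C[C@H](O)[C@H]2OC(=O)C(OCc3ccccc3)=C2OCc2ccccc2)nn1` gives 50 nM in this assay.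

Compound 1 stands level with compound 3 at the digits shown, within the scatter; its only other neighbour is a limit. Compound 2 sits at the limit of > 100000 nM in this assay, at which 1 of the 3 values shown sits.

Compound 4 `O=C1O[C@H]([C@@H](O)Cn2ccnn2)C(OCc2ccccc2)=C1OCc1ccccc1` differs from compound 1 in one place: hydrogen in place of (((4-methylphenyl)sulfonyl)amino)methyl on an aromatic carbon. Two measured steps start from compound 1 and change that same group. One is large: an at least 2000-fold higher number from compound 1 to compound 2 (3.30 log units; beyond the scatter). The other is none: no change at the digits printed from compound 1 to compound 3 (within the scatter). Between the two new groups the swing is just as large: an at least 2000-fold lower number from compound 2 to compound 3 (3.30 log units; beyond the scatter). So this position decides whether the number is small or beyond the limit, but neither step removes the group outright, so the direction for a bare hydrogen rests on thin ground.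

Compound 4 is therefore expected to give about 3000 nM, somewhere between 100 nM and 100000 nM. That estimate means a 60-fold higher number from compound 1 to compound 4 (1.78 log units; beyond the scatter), with a real chance that only a limit is reported.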

Compound 4, half-maximal inhibitory concentration: 610 nM
Beside the measured number, compound 4's estimate is 4.9-fold (0.69 log units) above it, within the range that was stated.
By their numbers in this assay, from the lowest: compounds 1 and 3 (each within the scatter of the next); then compound 4. At a limit, above all of these: compound 2.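

In this assay, the bare hydrogen shows that the shared core needs no large group on this aromatic carbon to give a measurable number. Two quite different groups each still lower that number compared with hydrogen: (((4-methylphenyl)sulfonyl)amino)methyl gives a 12-fold higher number from compound 1 to compound 4 (1.09 log units; beyond the scatter), and 2-methoxyphenyl gives a 12-fold higher number from compound 3 to compound 4 (1.09 log units; beyond the scatter). With 3,5-difluorophenyl the change runs the other way, with an at least 160-fold lower number from compound 2 to compound 4 (2.21 log units; beyond the scatter), a step read from a limit, so a group at this carbon can move the number in either direction from hydrogen.

The compounds shown leave open what a small group such as methyl, an amine or a carboxylic acid would do here. They also leave open which part of either lowering group accounts for its step.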